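A few compounds are considered here, and "the series" means these few. Any claim that something is new, unique, unknown or untested is made for them only; others in the source may bear on it.

Measured compounds:
- compound 1, `c1ccc(C(C2Cc3ccccc3O2)n2cncn2)cc1`, 85.7%
- compound 2, `c1ccc(C(C2Cc3ccccc3O2)n2cnnn2)cc1`, 35%
- compound 3, `O=[N+]([O-])c1ccc2c(c1)CC(C(c1ccccc1)n1cnnn1)O2`, 14.4%

In an assay for inhibition of Aromatase (Homo sapiens), tested at 20 uM (on this read-out lower numbers stand for less inhibition and higher numbers for more inhibition at the one concentration tested (going by the name of the read-out)), compound 2 sits in the middle of the three measured compounds: it gives 35%, which is second highest of the three numbers. Its nearest neighbour is compound 3, reached by a number 20.6 percentage points lower from compound 2 to compound 3 (beyond the scatter). Compound 1 lies furthest away, and the step of a number 50.7 percentage points lower from compound 1 to compound 2 (beyond the scatter) is large.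

Compound 4, `Clc1ccc(C(C2Cc3ccccc3O2)n2cnnn2)cc1`, is not yet measured. It differs from compound 2 in one place: chloro in place of hydrogen on an aromatic carbon.

Among the measured compounds shown here, only one measured step resembles this change: the step from compound 2 to compound 3, where a group entered on an aromatic carbon of the shared core and the number fell by a modest amount, a number 20.6 percentage points lower from compound 2 to compound 3 (beyond the scatter). The step from compound 1 to compound 2 concerns a different part of the molecule and says little here. A chloro group is a smaller change than a nitro group, and it enters a different ring, so the expectation is a small lowering or no change beyond the scatter.

Compound 4 is therefore expected to give 28% in this assay, within a range of 10% to 48%, which means an expected step of a number 7 percentage points lower from compound 2 to compound 4 (within the scatter).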

Compound 4, a percentage reported as inhibition, at one concentration (the size of the read-out at that concentration, not a potency): 90.3%
For compound 4 the middle estimate is 62.3 percentage points below the measured one; the whole stated range lies below it.
By their numbers in this assay, from the lowest: compound 3; then compound 2; then compounds 1 and 4 (each within the scatter of the next).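

In this assay, the change from phenyl to 4-chlorophenyl gives a number 55.3 percentage points higher from compound 2 to compound 4 (beyond the scatter), so one chlorine atom at this place raises the number by a large amount. The only earlier substitution on an aromatic carbon went the other way, with nitro giving a number 20.6 percentage points lower from compound 2 to compound 3 (beyond the scatter), so adding a group to an aromatic carbon of this series does not always lower the number; the two changes differ in both the group and its place, and these two effects cannot be separated here. No measurement at hand explains why the chloro group raises the number at this place.

On these data alone, it remains open whether this rise belongs to chloro in particular or would also appear with another group at the same place, such as fluoro, bromo, methyl or methoxy, and whether chloro would have a similar effect on the other aromatic ring. The compounds shown also do not tell whether 4-chlorophenyl would raise the number in the same way when the 1H-1,2,4-triazol-1-yl group takes the place of the 1H-tetrazol-1-yl group.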